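The source may hold more compounds than are shown below. What is called first, only, known or untested is meant among the compounds shown, and "the series" means these compounds.

Working notes on the series. The shared core carries a substituted acetamide on one side and a saturated nitrogen ring on the other. Compound 1 `Cc1nc(N2CCN(C3CCCC3)CC2)nc2ccc(NC(=O)COc3ccc(Cl)cc3)cc12` gives 150 nM in a functional assay on CHO-K1 cells for antagonist activity at melanin-concentrating hormone receptor 1 (Homo sapiens), read by inositol phosphate accumulation; on this read-out higher numbers stand for weaker inhibition and lower numbers for stronger inhibition. Compound 2 `CCC1(O)CCN(c2nc(C)c3cc(NC(=O)COc4ccc(OC(F)(F)F)cc4)ccc3n2)CC1` gives 59 nM in this assay, the lower of the two numbers that are available; the gap to compound 1 lies beyond the scatter. For the measured compounds named here, for compound 3 `Cc1nc(N2CCC(O)CC2)nc2ccc(NC(=O)C(C)(C)Oc3ccc(Cl)cc3)cc12` this assay returns only a limit, > 10000 nM, and not a number; it is the one value resting at the limit of > 10000 nM in this assay, at which 1 of the 3 values shown sits.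

Compound 4 `Cc1nc(N2CCN(C3CCOCC3)CC2)nc2ccc(NC(=O)COc3ccc(OC(F)(F)F)cc3)cc12` has not been measured. It differs from compound 2 by 4-(oxan-4-yl)piperazin-1-yl in place of 4-ethyl-4-hydroxypiperidin-1-yl on an aromatic carbon. The closest measured reference for the entering group is compound 1, whose cyclopentylpiperazine partner sits on the same carbon; in this assay compound 1 gives 150 nM, while compound 2 keeps the same aryl ether as compound 4. The step from compound 2 to compound 4 is expected to be small, a 1.5-fold higher number from compound 2 to compound 4 (0.18 log units; within the scatter), toward a somewhat higher number but within the scatter. Compound 4 is therefore estimated at 90 nM, with a range from 30 nM to 300 nM.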

Compound 4, half-maximal inhibitory concentration: 31 nM
For compound 4 the middle estimate is 2.9-fold (0.46 log units) above the measured one; measured number inside the range.
By their numbers in this assay, from the lowest: compounds 4 and 2 (each within the scatter of the next); then compound 1. At a limit, above all of these: compound 3.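

In this assay, for the compounds shown here, the exchange of 4-ethyl-4-hydroxypiperidin-1-yl for 4-(oxan-4-yl)piperazin-1-yl gives a 1.9-fold lower number from compound 2 to compound 4 (0.28 log units; within the scatter), the first single-place step. With the aryl ether held constant, the aromatic carbon between two ring nitrogen atoms therefore accepts a group with more heavy atoms and no hydrogen-bond donor, so the hydroxyl of the leaving group is not needed to keep the number in this range for this pair. Nothing measured in the series bears on the cause of this step.

Going by these compounds, whether a morpholine or an open-chain dimethylamino group on the same carbon would keep the value stays open, as does whether the exchange holds with other aryl ethers. For compound 3 the value > 10000 nM is a limit, and no compound shown differs from it in one place, so it cannot be tied to a single group.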